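Aryl Swap on the Amine Nitrogen of Compound 2

A few compounds are considered here, and "the series" means these few. Any claim that something is new, unique, unknown or untested is made for them only; others in the source may bear on it.

Of the compounds shown here, two carry numbers so far. Compound 1 `CCOC(=O)C1=C(Nc2ccccc2)S/C(=C\c2ccc(O)c(O)c2)C1=O` gives 48.7% in a functional assay on JAR cells (Homo sapiens) for inhibition, read by MTT assay, with a stated time of 72 h, tested at 10 uM; a higher number here means more inhibition at the concentration tested (going by the name of the read-out), a lower number less inhibition. Compound 2 `CCOC(=O)C1=C(Nc2ccccc2Br)S/C(=C\c2ccc[nH]2)C1=O` gives 62.7% in this assay and stands highest of the two; its gap to compound 1 lies beyond the usual scatter. Compound 1 and compound 2 differ at two places at once, so that gap says nothing about either place alone.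

Compound 3 `CCOC(=O)C1=C(Nc2ccc(C)cc2)S/C(=C\c2ccc[nH]2)C1=O` has no number yet in this assay. Against compound 2 the change is 4-methylphenyl in place of 2-bromophenyl on an amine nitrogen. Among the compounds with values here, no measured pair shows this change, so its size has no anchor in the numbers at hand. Without such an anchor the step from compound 2 to compound 3 is expected to be small, likely within the scatter and of uncertain direction: a number 7.7 percentage points lower from compound 2 to compound 3 (within the scatter). Compound 3 is accordingly estimated at 55% in this assay, with a range from 35% to 75%.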

Compound 3, a percentage reported as inhibition, at one concentration (the size of the read-out at that concentration, not a potency): < 10%
Compound 3 ended at the assay's limit; the forecaster's own chance of this, stated with the estimate: 0%; middle value at least 45 percentage points away from the limit.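

The aryl group on the amine nitrogen now has its first single-place reading, which the two-place gap between compound 1 and compound 2 could not give: 4-methylphenyl in place of 2-bromophenyl yields a number at least 52.7 percentage points lower from compound 2 to compound 3 (beyond the scatter) in this assay. This position is therefore not a neutral one, as a swap of one aryl group for another of equal heavy-atom count is enough on its own to produce a large step with the rest of compound 2 unchanged. The value of compound 3, < 10%, is a limit of the assay and not a number.

The names 2-bromophenyl and 4-methylphenyl differ in both the substituent and its numbered place on the ring, and the compounds shown leave open which of the two carries the step. A 4-bromophenyl or a 2-methylphenyl group on the same amine nitrogen, with the rest of compound 2 kept, would separate the two.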